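Amide-to-sulfonamide swap in a tert-butylamide sulfonamide series

A few compounds are considered here, and "the series" means these few. Any claim that something is new, unique, unknown or untested is made for them only; others in the source may bear on it.

Compound 1 `Cc1ccc(S(=O)(=O)N[C@@H](CC(=O)NC(C)(C)C)C(=O)NCCNC(=O)c2cc(Cl)ccn2)cc1` gives a limit in an ADME assay on Karpas-1106P cells (Homo sapiens) for cytotoxicity; on this read-out higher numbers stand for an effect only at larger amounts of compound and lower numbers for an effect already at smaller amounts: > 11100 nM.
Compound 2 `Cc1ccc(S(=O)(=O)N[C@@H](CC(=O)NC(C)(C)C)C(=O)NCCNC(=O)c2cccc(O)c2)cc1` gives a limit in this assay: > 11100 nM.
Compound 3 `Cc1ccc(S(=O)(=O)N[C@@H](CC(=O)NC(C)(C)C)C(=O)NCCNC(=O)c2cccc(C#N)c2)cc1` gives a limit in this assay: > 11100 nM.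

Compound 1 stands only at a limit, as do the other two measured compounds (the limit of > 11100 nM in this assay, at which 3 of the 3 values shown sit). The steps from it, a step that the two limits leave unreadable from compound 1 to compound 2 and a step that the two limits leave unreadable from compound 1 to compound 3, are therefore unreadable, and the step that the two limits leave unreadable from compound 2 to compound 3 is equally unreadable.

Compound 4 `Cc1ccc(S(=O)(=O)N[C@@H](CC(=O)NC(C)(C)C)C(=O)NCCNS(=O)(=O)c2ccccc2)cc1` differs from compound 1 by phenylsulfonyl in place of (4-chloropyridin-2-yl)carbonyl on an amine nitrogen. For the measured compounds named here, no measured step bears on this change, and no measured compound carries a phenylsulfonyl group at this position. With every value sitting at the limit, compound 4 is expected to return a limit as well, with a number no higher from compound 1 to compound 4 (the limit leaves the size open) meaning no readable step beyond the scatter. Compound 4 is estimated at 11100 nM (range 6000 nM to 30000 nM).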

Compound 4, half-maximal effective concentration: > 11100 nM
Compound 4 ended at the assay's limit; the forecaster's own chance of this, stated with the estimate: 85%; the middle value lies on the limit itself.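

Compound 1, compound 2, compound 3 and compound 4 all give limits in this assay, so the steps among them cannot be read: the limit of > 11100 nM in this assay, at which 4 of the 4 values shown sit.

The compounds shown leave open whether any group on this amine nitrogen changes the read-out.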